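This account rests on a few compounds, and the source may have more. Where it says the series, first, only, none or still open, it means among the compounds named here.

Compound 1 `Cc1cc(C(=O)c2ccccc2)ccc1OCC(=O)Nc1nc(-c2ccccc2)cs1`: 21500 nM
Compound 2 `COc1ccc(-c2csc(NC(=O)COc3ccc(C(=O)c4ccccc4)cc3C)n2)cc1`: 24200 nM

Both numbers come from a functional assay on DLA cells (Mus musculus) for cytotoxicity, read by trypan blue exclusion, with a stated time of 48 h; on this read-out higher numbers stand for weaker inhibition and lower numbers for stronger inhibition. For the measured compounds named here, compound 1 stands lowest of the two, but only just, since the one measured step, a 1.1-fold higher number from compound 1 to compound 2 (0.05 log units; within the scatter), lies within the scatter; that step adds a methoxy on an aromatic carbon of the phenyl attached to the thiazole.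

Compound 3 `Cc1cc(C(=O)c2cccc(Br)c2)ccc1OCC(=O)Nc1nc(-c2ccccc2)cs1` differs from compound 1 in a different place: bromo in place of hydrogen on an aromatic carbon. Going by the values given here, no measured step touches this ring, so the only guide is the general picture that a small single-atom addition elsewhere, a 1.1-fold higher number from compound 1 to compound 2 (0.05 log units; within the scatter), left the number essentially unchanged. On that basis no step beyond the scatter is expected in this assay in either direction. Compound 3 is therefore expected to give about 18000 nM, with a plausible range from 8000 nM to 45000 nM. Compound 3 is thus expected to show a 1.2-fold lower number from compound 1 to compound 3 (0.08 log units; within the scatter).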

Compound 3, half-maximal inhibitory concentration: 21700 nM
For compound 3 the middle estimate is 1.2-fold (0.08 log units) below the measured one; low and high end bracket the measured number.
By their numbers in this assay, from the lowest: compounds 1, 3 and 2 (each within the scatter of the next).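

The earlier pair changed only the phenyl attached to the thiazole, while this step reaches the benzoyl end of the molecule: going from phenyl to 3-bromophenyl gives a 1.0-fold higher number from compound 1 to compound 3 (0.00 log units; within the scatter) in this assay. A bromo on this aromatic carbon, meta to a large group, therefore leaves the two compounds indistinguishable in this read-out, so this position accepts that single heavy atom without a measurable penalty. Nothing available here explains this outcome, and it stands as an observation only.

Still open, as far as these compounds go, is whether an amine, a carboxylic acid or a longer alkyl chain at this position would separate from compound 1 by more than the scatter. Also open, from the compounds shown here alone, is whether a bromo elsewhere on this ring would behave the same way.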